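Working notes: one change, two cores, cytotoxicity

The compounds below may be only part of what the source reports. "The series", "measured", "known", "first", "only" and "open" are said of these compounds alone.

Measured so far:
- compound 1 `CN(N=O)C(=O)NC[C@H]1O[C@@H](n2cnc3c(N)ncnc32)[C@H](O)[C@@H]1O`: in a functional assay on HEp-2 cells (Homo sapiens) for cytotoxicity (a higher number here means that more compound is needed for the effect, a lower number that less compound is needed), compound 1 gives 40 uM
- compound 2 `CN(N=O)C(=O)N[C@H]1[C@@H](O)[C@H](n2ccc(N)nc2=O)O[C@@H]1CO`: in this assay compound 2 gives > 50 uM, which is a limit of the assay and not a number
- compound 3 `CNC(=O)NC[C@H]1O[C@@H](n2cnc3c(N)ncnc32)[C@H](O)[C@@H]1O`: in this assay compound 3 gives > 60 uM, again a limit of the assay and not a number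

The change from compound 1 to compound 3 is a hydrogen atom in place of a group of 2 heavy atoms (1 nitrogen, 1 oxygen; no ring), on an amide-type nitrogen. Its size in this assay is an at least 1.5-fold higher number from compound 1 to compound 3 (0.17 log units; that floor lies within the scatter); the step carries only a floor because of the limit of > 60 uM in this assay, at which 1 of the 3 values shown sits. The same change is made from compound 2 to compound 4 `CNC(=O)N[C@H]1[C@@H](O)[C@H](n2ccc(N)nc2=O)O[C@@H]1CO`, namely (a hydrogen atom in place of a group of 2 heavy atoms (1 nitrogen, 1 oxygen; no ring), on an amide-type nitrogen); the place is described in identical words for both pairs, so this is the same change on a second core. The difference between the two cores of compound 1 and compound 2 is not broken down here.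

Compound 2 already sits at a limit, as the limit of > 50 uM in this assay, at which 1 of the 3 values shown sits, records. The change is expected to move compound 4 by a step that the limit leaves unreadable from compound 2 to compound 4, resting on an at least 1.5-fold higher number from compound 1 to compound 3 (0.17 log units; that floor lies within the scatter), where the same change did not lower the number. Compound 4 is therefore estimated at 120 uM, with a range from 50 uM to 400 uM, and a reported limit rather than a number is the likelier outcome.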

Compound 4, concentration for half-maximal effect: > 60 uM
Compound 4: no number, only a limit; the forecaster's own chance of this, stated with the estimate: 85%; the middle value is on the limit's open side.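

Within the data shown here, compound 2 and compound 4 both sit at limits of the assay in this assay, and no step between them can be read. The compounds shown leave open how large the change from the group on the amide-type nitrogen to a hydrogen atom really is on either core, and whether compound 2 and compound 4 differ at all.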